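A few compounds are considered here, and "the series" means these few. Any claim that something is new, unique, unknown or untested is made for them only; others in the source may bear on it.

Measured compounds and their readings:

Compound 1, `COc1cc2c(cc1OC)CN(Cc1ccc(OC)c3oc(-c4cccc(C#N)c4)cc13)CC2`, gives 42% in an assay on HepG2 cells for displacement of a labelled ligand from Alpha-2C adrenergic receptor (Homo sapiens), tested at 0.1 uM; a higher number here means more inhibition at the concentration tested (going by the name of the read-out), a lower number less inhibition.
Compound 2, `COc1cc2c(cc1OC)CN(Cc1ccc(OC)c3oc(-c4cccc(C(=O)NCCO)c4)cc13)CC2`, gives 54% in this assay.
Compound 3, `CCCNC(=O)c1cc2c(CN3CCc4cc(OC)c(OC)cc4C3)ccc(OC)c2o1`, gives 20% in this assay.

Among these three, compound 3 stands lowest: a number 22 percentage points lower from compound 1 to compound 3 (beyond the scatter), and a number 34 percentage points lower from compound 2 to compound 3 (beyond the scatter). Compound 1 is its nearest neighbour in the numbers, compound 2 the furthest. Among the compounds with values here, the only other measured step, a number 12 percentage points higher from compound 1 to compound 2 (beyond the scatter), concerns a change at a different part of the shared core and so does not speak directly to what follows.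

Compound 4, `COc1cc2c(cc1OC)CN(Cc1ccc(OC)c3oc(C(=O)NCCNC(C)=O)cc13)CC2`, has not yet been measured in this assay. It differs from compound 3 in one place: acetamido in place of methyl on a saturated chain carbon, two bonds along the chain from an amide-type nitrogen. Within the data shown here, none of the three measured steps changes this chain, so there is no measured step that bears on it directly. Compound 4 is therefore expected to stay close to compound 3, with a step of a number 5 percentage points higher from compound 3 to compound 4 (within the scatter), which would lie within the usual scatter. Compound 4 is accordingly estimated at 25% in this assay, with a range from 5% to 45%.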

Compound 4, a percentage reported as inhibition, at one concentration (the size of the read-out at that concentration, not a potency): 9%
The estimate for compound 4 lay 16 percentage points above the measured number; measured number inside the range.
By their numbers in this assay, from the lowest: compound 4; then compound 3; then compound 1; then compound 2.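

In this assay, the far end of the chain on the amide nitrogen affects the reading: acetamido in place of methyl on a saturated chain carbon, two bonds along the chain from an amide-type nitrogen, gives a number 11 percentage points lower from compound 3 to compound 4 (beyond the scatter) as a modest drop beyond the scatter. This adds a second amide to the chain, yet the reading falls further, and a larger group at this place therefore brings no gain here. Replacing the aromatic groups on the shared core with (2-acetamidoethyl)carbamoyl gives a number 33 percentage points lower from compound 1 to compound 4 (beyond the scatter) and a number 45 percentage points lower from compound 2 to compound 4 (beyond the scatter) as large drops, leaving compound 4 the lowest of the four, and no supporting data are available to explain these drops.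

With only propyl and 2-acetamidoethyl as chains on this amide, two compounds cannot show whether the drop follows from the chain's length or from the acetamido group itself. A plain butyl chain of similar length, or a chain ending in an amine, a hydroxyl or a carboxylic acid, would help separate these two readings.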